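One more fluoro on the 2,3,6-trifluorophenyl group

This account rests on a few compounds, and the source may have more. Where it says the series, first, only, none or still open, it means among the compounds named here.

Within the data shown here, in a functional assay on Jurkat cells (Homo sapiens) (a lower number here means a stronger inhibitor, a higher number a weaker inhibitor), compound 3 `CC(C)[C@H](NC(=O)COc1cccc2ccccc12)C(=O)N[C@@H](CC(=O)O)C(=O)COc1c(F)ccc(F)c1F` gives 1200 nM as the only true number so far. Compound 1 `CC(C)[C@H](NC(=O)COc1cccc2ccccc12)C(=O)N[C@@H](CC(=O)O)C(=O)COc1ccccc1[N+](=O)[O-]` gives > 100000 nM as a limit of the assay. Compound 2 `CC(C)[C@H](NC(=O)COc1cccc2ccccc12)C(=O)N[C@@H](CC(=O)O)C(=O)COc1cc(F)cc(F)c1` gives > 100000 nM as a limit too. Compound 4 `CC(C)[C@H](NC(=O)COc1cccc2ccccc12)C(=O)N[C@@H](CC(=O)O)C(=O)COc1c(F)c(F)cc(F)c1F` has fluoro in place of hydrogen on an aromatic carbon, so 2,3,6-trifluorophenyl becomes 2,3,5,6-tetrafluorophenyl fluoro in place of hydrogen on an aromatic carbon in this comparison. Both an at least 83-fold lower number from compound 1 to compound 3 (1.92 log units; beyond the scatter) and an at least 83-fold lower number from compound 2 to compound 3 (1.92 log units; beyond the scatter) are large steps, yet each swaps a whole group rather than adding one fluoro. Only a small move towards a lower number is therefore expected, perhaps none beyond the scatter. The expected change is a 1.5-fold lower number from compound 3 to compound 4 (0.18 log units; within the scatter) by this estimate. For compound 4 the estimated value is 800 nM (expected range 150 nM to 4500 nM).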

Compound 4, half-maximal inhibitory concentration: 4500 nM
Compound 4: the middle estimate sits 5.6-fold (0.75 log units) below what was measured; the range from low to high includes it.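

In this assay, fluoro in place of hydrogen on this aromatic carbon gives a 3.8-fold higher number from compound 3 to compound 4 (0.57 log units; beyond the scatter), so a single added atom on this ring can move the number upward, beyond the scatter. Even so, the tetrafluorophenyl group keeps a clear gain over the other two rings, with an at least 22-fold lower number from compound 2 to compound 4 (1.34 log units; beyond the scatter) and an at least 22-fold lower number from compound 1 to compound 4 (1.34 log units; beyond the scatter). Those two steps rest on a limit, not on true numbers: the limit of > 100000 nM in this assay, at which 2 of the 4 values shown sit. Going by these compounds, what chloro or a methoxy group on this same carbon would give stays open. So does the question of which fluoro groups of compound 3 matter most.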